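Hydroxyformamide sulfone series: diaryl ether in place of biphenyl

The source may hold more compounds than are shown below. What is called first, only, known or untested is meant among the compounds shown, and "the series" means these compounds.

Measured so far:
- compound 1 `COc1ccc(S(=O)(=O)C(Cc2cccc3ccccc23)C(=O)NO)cc1`: 197 nM
- compound 2 `CC1(C)NC(=O)N(CC(CS(=O)(=O)c2ccc(-c3ccc(OC(F)(F)F)cc3)cc2)N(O)C=O)C1=O`: 0.34 nM

In an assay on isolated protein for inhibition of matrix metalloproteinase-9 (Homo sapiens) (on this read-out higher numbers stand for weaker inhibition and lower numbers for stronger inhibition), compound 1 gives 197 nM and compound 2 gives 0.34 nM. Compound 2 stands lowest of the two numbers, and the gap to compound 1 lies far beyond the scatter; the two structures differ in many places, so no single step can be read from that pair.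

Compound 3 `CC1(C)NC(=O)N(CC(CS(=O)(=O)c2ccc(Oc3ccc(Cl)cc3)cc2)N(O)C=O)C1=O` keeps the core of compound 2 and differs from it in one place: 4-chlorophenoxy in place of 4-(trifluoromethoxy)phenyl on an aromatic carbon. For the measured compounds named here, no measured pair shows a step of this kind, so the expectation for compound 3 rests on compound 2 alone. A shift no larger than the scatter is expected, with no direction preferred, since compound 2 already gives 0.34 nM in this assay. Compound 3 is therefore estimated at 0.4 nM, within 0.1 nM to 1.5 nM, a step of a 1.2-fold higher number from compound 2 to compound 3 (0.07 log units; within the scatter) in expectation.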

Compound 3, half-maximal inhibitory concentration: 37 nM
Beside the measured number, compound 3's estimate is 93-fold (1.97 log units) below it; measured number outside the range, above it.
By their numbers in this assay, from the lowest: compound 2; then compound 3; then compound 1.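

At this position, on an aromatic carbon para to a large group, the read-out in this assay responds strongly to the group carried: 4-chlorophenoxy in place of 4-(trifluoromethoxy)phenyl gives a 110-fold higher number from compound 2 to compound 3 (2.04 log units; beyond the scatter). This one step alters two features together, since the aromatic ring is now joined through oxygen and its own substituent is chlorine rather than trifluoromethoxy. Nothing measured here bears on the reason for the step.

Which of the two features carries the step stays open; a 4-chlorophenyl or a 4-(trifluoromethoxy)phenoxy group at this position would separate them. Also open, on these data alone, is whether the number at this position follows the ring substituent more generally, for instance with a nitrile or a methoxy group in place of chlorine.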